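Naphthalen-1-yl Replaces Trifluoromethylphenyl on the Amide Nitrogen

A few compounds are considered here, and "the series" means these few. Any claim that something is new, unique, unknown or untested is made for them only; others in the source may bear on it.

In a functional assay on THP-1 cells (Homo sapiens) for inhibition (on this read-out lower numbers stand for stronger inhibition and higher numbers for weaker inhibition), compound 2 `C[C@H](NC(=O)C(=O)Nc1ccccc1C(F)(F)F)C(=O)N[C@@H](CC(=O)O)C(=O)COc1c(F)c(F)cc(F)c1F` gives 190 nM, and compound 1 `C[C@H](NC(=O)C(=O)Nc1ccccn1)C(=O)N[C@@H](CC(=O)O)C(=O)COc1c(F)c(F)cc(F)c1F` gives 200 nM. These two numbers lie within the scatter of each other, which the step of a 1.1-fold lower number from compound 1 to compound 2 (0.02 log units; within the scatter) confirms. Compound 3 `C[C@H](NC(=O)C(=O)Nc1cccc2ccccc12)C(=O)N[C@@H](CC(=O)O)C(=O)COc1c(F)c(F)cc(F)c1F` differs from compound 2 by naphthalen-1-yl in place of 2-(trifluoromethyl)phenyl on an amide-type nitrogen. For the measured compounds named here, the only step that bears on this change is that earlier exchange of the group on the same nitrogen, which left the number essentially unchanged. A step of similar size, none beyond the scatter, is therefore expected: a 1.1-fold higher number from compound 2 to compound 3 (0.02 log units; within the scatter). Compound 3 is estimated at 200 nM, between 80 nM and 500 nM.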

Compound 3, half-maximal inhibitory concentration: 60 nM
Compound 3: the middle estimate sits 3.3-fold (0.52 log units) above what was measured, and the stated range ends above it.
By their numbers in this assay, from the lowest: compound 3; then compounds 2 and 1 (each within the scatter of the next).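

In this assay the group on this amide-type nitrogen does move the number: naphthalen-1-yl gives a 3.2-fold lower number from compound 2 to compound 3 (0.50 log units; beyond the scatter) and also a 3.3-fold lower number from compound 1 to compound 3 (0.52 log units; beyond the scatter), whereas the earlier exchange on the same nitrogen stayed within the scatter. The entering and leaving groups of compound 2 and compound 3 both hold 10 heavy atoms, so that count alone does not separate them. Nothing shown here accounts for the step. The compounds shown leave open whether naphthalen-2-yl or an unsubstituted phenyl on this nitrogen would give a number like that of compound 3 or like those of compound 1 and compound 2.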